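A Benzyl Swap Tested on Compound 1

The source may report more compounds than this note shows. Statements on the series, on what has been measured and on what is new or still open speak of the compounds shown alone.

Among the compounds with values here, compound 1 `N#Cc1c(Nc2ccccc2Cl)nc(SCc2cn(Cc3ccccc3Cl)nn2)nc1-c1ccccc1` gives 8350 nM in a functional assay on B16-F10 cells (Mus musculus) for inhibition, read by MTT assay, with a stated time of 72 h (on this read-out lower numbers stand for stronger inhibition and higher numbers for weaker inhibition), the highest of the two numbers known so far. Compound 2 `N#Cc1c(Nc2ccc(F)cc2)nc(SCc2cn(Cc3ccccc3Cl)nn2)nc1-c1ccccc1` gives 5340 nM in this assay, and the step of a 1.6-fold lower number from compound 1 to compound 2 (0.19 log units; within the scatter) changes a group on an aromatic nitrogen. Compound 3 `Cc1ccc(Cn2cc(CSc3nc(Nc4ccccc4Cl)c(C#N)c(-c4ccccc4)n3)nn2)cc1` differs from compound 1 by 4-methylphenyl in place of 2-chlorophenyl on a saturated chain carbon bound to an aromatic nitrogen, a change at another place. Within the data shown here, no measured step touches that place, so the only guide is that the single step seen stayed within the scatter. For compound 3 the expected step is a 1.0-fold lower number from compound 1 to compound 3 (0.02 log units; within the scatter), nothing beyond the scatter, giving an estimate of 8000 nM with a range from 3000 nM to 20000 nM.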

Compound 3, half-maximal inhibitory concentration: 7080 nM
Beside the measured number, compound 3's estimate is 1.1-fold (0.05 log units) above it, within the range that was stated.
By their numbers in this assay, from the lowest: compounds 2, 3 and 1 (each within the scatter of the next).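

In this assay, within the data shown here, there is a 1.2-fold lower number from compound 1 to compound 3 (0.07 log units; within the scatter) on replacing 2-chlorobenzyl with 4-methylbenzyl, the first reading at this place, on a saturated chain carbon bound to an aromatic nitrogen. The two benzyl groups therefore cannot be told apart here, so this exchange leaves the number within the scatter. Nothing available explains this result. Still open, from the compounds shown here alone, is whether a benzyl ring carrying an amine or a carboxylic acid, or a longer chain in place of benzyl, would shift the number beyond the scatter.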